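Phenylethyl versus methyl on two related urea cores

The source may report more compounds than this note shows. Statements on the series, on what has been measured and on what is new or still open speak of the compounds shown alone.

Measured compounds:
compound 1 `CC(NC(=O)/C=C/c1ccc(NC(=O)Nc2ccc(Cl)c(C(F)(F)F)c2)cc1)c1ccccc1`, 20800 nM
compound 2 `CNC(=O)/C=C/c1ccc(NC(=O)Nc2ccc(Cl)c(C(F)(F)F)c2)cc1`, 20900 nM
compound 3 `CNC(=O)/C=C(\C)c1ccc(NC(=O)Nc2ccc(Cl)c(C(F)(F)F)c2)cc1`, > 50000 nM

All three were tested in a functional assay on A-375 cells (Homo sapiens) for inhibition, read by MTT assay, with a stated time of 120 h; a higher number here means a weaker inhibitor, a lower number a stronger inhibitor. For compound 3 the reading is a limit of the assay, not a number, namely > 50000 nM. The two cores differ by 1-methyl-2-(methylcarbamoyl)ethenyl in place of 2-(methylcarbamoyl)ethenyl on an aromatic carbon, and the step of an at least 2.3-fold higher number from compound 2 to compound 3 (0.37 log units; beyond the scatter) can only be given as a bound because of the limit of > 50000 nM in this assay, at which 1 of the 3 values shown sits.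

The change 1-phenylethyl in place of methyl on an amide-type nitrogen made the step of a 1.0-fold lower number from compound 2 to compound 1 (0.00 log units; within the scatter), so swapping methyl for 1-phenylethyl left the reading essentially unchanged on the core of compound 2.

Compound 4 `C/C(=C\C(=O)NC(C)c1ccccc1)c1ccc(NC(=O)Nc2ccc(Cl)c(C(F)(F)F)c2)cc1`, not yet measured, applies the same change to compound 3: 1-phenylethyl in place of methyl on an amide-type nitrogen. The place is described in identical words for both pairs, so this is the same change on a different core. Since the earlier step of a 1.0-fold lower number from compound 2 to compound 1 (0.00 log units; within the scatter) was flat, compound 4 is expected to stay near compound 3, with an estimated step that the limit leaves unreadable from compound 3 to compound 4. Compound 4 is therefore estimated at 60000 nM, most likely again reported only as a limit.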

Compound 4, half-maximal inhibitory concentration: > 50000 nM
Compound 4: only a limit was reported (the forecaster's own chance of this, stated with the estimate: 75%); the middle value lies beyond the limit too.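

Compound 3 and compound 4 are each reported only as a limit of the assay, not as a number, so no step can be read between them: the limit of > 50000 nM in this assay, at which 2 of the 4 values shown sit.

From the compounds shown here alone, what stays open is how the two really compare, and whether 1-phenylethyl in place of methyl changes as little on the core of compound 3 as it does on the core of compound 2.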